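Swapping dimethylamino for piperidin-1-yl on the shared core

A few compounds are considered here, and "the series" means these few. Any claim that something is new, unique, unknown or untested is made for them only; others in the source may bear on it.

Of the compounds shown here, three built on one core have been measured in an ADME assay on L6 cells (Rattus norvegicus) for cytotoxicity; on this read-out lower numbers stand for stronger inhibition and higher numbers for weaker inhibition. Compound 1 (`O=C(CN1CCCC1)OC1CC2(N3CCCCC3)CC(c3ccccc3)C1C(c1ccccc1)C2`) gives 16400 nM; 52000 nM (2 entries), so it has no single number. Compound 2 (`CCN(CC)CCC(=O)OC1CC2(N3CCCCC3)CC(c3ccccc3)C1C(c1ccccc1)C2`) gives 22900 nM. Compound 3 (`CN(C)C12CC(OC(=O)CCN3CCCC3)C(C(c3ccccc3)C1)C(c1ccccc1)C2`) gives 26000 nM, which lies within the usual scatter of the value of compound 2, and the two entries of compound 1 fall on either side of both.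

The next compound to be read is compound 4 (`O=C(CCN1CCCC1)OC1CC2(N3CCCCC3)CC(c3ccccc3)C1C(c1ccccc1)C2`). It keeps the ((2-(pyrrolidin-1-yl)ethyl)carbonyl)oxy group of compound 3 and carries piperidin-1-yl in place of dimethylamino on a saturated ring carbon. For the measured compounds named here, no measured pair of compounds isolates this change. Compound 1 and compound 2 also carry piperidin-1-yl, but they differ from compound 3 in the ester side chain as well. Even so, compound 2 carries piperidin-1-yl and gives 22900 nM, so no step beyond the scatter is expected in this assay, in either direction. The expected size of the change is a 1.1-fold lower number from compound 3 to compound 4 (0.03 log units; within the scatter), which is within the scatter. Compound 4 is estimated at 24000 nM, with an expected range from 11000 nM to 50000 nM.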

Compound 4, half-maximal inhibitory concentration: 12500 nM
Compound 4: the middle estimate sits 1.9-fold (0.28 log units) above what was measured; the range from low to high includes it.
By their numbers in this assay, from the lowest: compounds 4, 2 and 3 (each within the scatter of the next, the first and the last beyond it).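

In this assay, the change from dimethylamino to piperidin-1-yl on a saturated ring carbon can now be read on its own, with the ((2-(pyrrolidin-1-yl)ethyl)carbonyl)oxy group held constant, and it gives a 2.1-fold lower number from compound 3 to compound 4 (0.32 log units; beyond the scatter), a modest step. With piperidin-1-yl held constant, pyrrolidin-1-yl in place of diethylamino on a saturated chain carbon, two bonds along the chain from a carbonyl carbon, gives a 1.8-fold lower number from compound 2 to compound 4 (0.26 log units; within the scatter), so this side-chain change cannot be told apart from repeat measurement. Compound 1, which also carries piperidin-1-yl, gives no readable step to compound 4 because its two entries disagree: the several entries of compound 1 in this assay, 16400 nM; 52000 nM (2 entries)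

For the compounds shown here, this single pair leaves open whether the step at the ring carbon holds when the ester side chain is the one carried by compound 2. It also leaves open whether a morpholin-4-yl group or a primary amine at that ring carbon would read like piperidin-1-yl or like dimethylamino, and so whether the ring itself or only the larger group goes with the lower number.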